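The source may hold more compounds than are shown below. What is called first, only, known or untested is meant among the compounds shown, and "the series" means these compounds.

Working notes on the alkyl chain series. In a functional assay on HEL cells (Homo sapiens) (a higher number here means that more compound is tolerated, a lower number that less compound is tolerated), compound 1 (`CCCCc1cc2cn(COCCO)c(=O)nc2o1`) gives > 200000 nM as a limit of the assay. Compound 2 (`CCCCCCc1cc2cn(COCCO)c(=O)nc2o1`) gives > 200000 nM and this too is only a limit, so it has no number of its own and sits on the limit of > 200000 nM in this assay, at which 2 of the 2 values shown sit, in the series. Compound 3 (`CCCCCCCCCCc1cc2cn(COCCO)c(=O)nc2o1`) differs from compound 2 by butyl in place of hydrogen on a saturated chain carbon, six bonds along the chain from an aromatic carbon in the chain. For the measured compounds named here, the only measured step (a step that the two limits leave unreadable from compound 1 to compound 2) has no readable size, so it gives no firm guide to this assay and only a small fall in tolerated concentration is expected. The estimated step is an at least 1.1-fold lower number from compound 2 to compound 3 (0.07 log units; that floor lies within the scatter) and it stays modest. For compound 3 the expected value is 170000 nM with an estimated range from 60000 nM to 200000 nM in this reading.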

Compound 3, half-maximal cytotoxic concentration: > 200000 nM
Compound 3 ended at the assay's limit; the forecaster's own chance of this, stated with the estimate: 65%; at least 1.1-fold (0.07 log units) between middle value and limit.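

Compound 1, compound 2 and compound 3 all stay at a limit in this assay, so no step among them can be read: the limit of > 200000 nM in this assay, at which 3 of the 3 values shown sit.

The compounds shown leave open whether chain length changes the tolerated concentration at all.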